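The source may hold more compounds than are shown below. What is called first, only, known or untested is meant among the compounds shown, and "the series" means these compounds.

Three compounds, each built around a hydrazide that carries a saturated chain on its outer nitrogen, have been measured. Compound 1 `CCCCCCNNC(=O)c1ccc(-c2ccc(CNC(C)=O)cc2)cc1` gives 36 nM in an assay on isolated protein for inhibition of histone deacetylase 8 (Homo sapiens), read by fluorescence, with a stated time of 5 min; a lower number here means a stronger inhibitor, a higher number a weaker inhibitor. Compound 3 `CCCCCCNNC(=O)c1cnc(NCc2cccc3ccccc23)nc1` gives 63 nM in this assay, and compound 2 `CCCNNC(=O)c1cnc(NCc2ccccc2)nc1` gives 1000 nM in this assay. Compound 1 stands at the lowest of the three numbers; its gap to compound 3 lies within the usual scatter of such measurements, while its gap to compound 2 lies beyond it.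

Compound 4 `CCCCNNC(=O)c1ccc(-c2ccc(CNC(C)=O)cc2)cc1` has not yet been measured. It differs from compound 1 only by hydrogen in place of ethyl on a saturated chain carbon, four bonds along the chain from an amine nitrogen; the core and the acetamide-bearing arm are unchanged. Among the measured compounds shown here, no measured pair shows this change by itself, and compound 2, which carries a shorter chain, also has a different core, so it cannot isolate the effect of chain length. The step from compound 1 to compound 4 is therefore expected to be small, a 1.7-fold higher number from compound 1 to compound 4 (0.22 log units; within the scatter), leaning toward a higher number but likely staying within the scatter. Compound 4 is estimated at 60 nM, with a range from 25 nM to 150 nM.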

Compound 4, half-maximal inhibitory concentration: 360 nM
Compound 4: the middle estimate sits 6.0-fold (0.78 log units) below what was measured; the whole stated range lies below it.
By their numbers in this assay, from the lowest: compounds 1 and 3 (each within the scatter of the next); then compound 4; then compound 2.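

In this assay, replacing ethyl with hydrogen on a saturated chain carbon, four bonds along the chain from an amine nitrogen, gives a 10-fold higher number from compound 1 to compound 4 (1.00 log units; beyond the scatter) while the core and the acetamide-bearing arm stay the same. Among the compounds shown here, this is the first pair to isolate a change in chain length, and it shows that the outer two carbons of this chain, which carry no ring and no hydrogen-bond donors or acceptors, shift the number by more than the usual scatter. Nothing available explains why removing them has this effect.

Going by these compounds, whether the same shortening would give a step of similar size on the core of compound 3 remains open. So does the effect of a longer chain, or of a chain ending in an amine or a carboxylic acid, at this position.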